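The source may hold more compounds than are shown below. What is called first, only, known or untested is meant among the compounds shown, and "the series" means these compounds.

Measured in a functional assay on DU-145 cells (Homo sapiens) for inhibition, read by trypan blue exclusion, with a stated time of 96 h; a higher number here means a weaker inhibitor of growth, a lower number a stronger inhibitor of growth:
- Compound 1 `O=C(O)c1ccc(C(=O)/C(=C\c2ccc(O)c([N+](=O)[O-])c2)SCc2ccc(Br)cc2)cc1`: 50000 nM
- Compound 2 `O=C(/C(=C\c1ccc(O)c([N+](=O)[O-])c1)SCc1ccc(Br)cc1)c1ccc(Br)cc1`: 10000 nM
- Compound 3 `O=C(/C(=C\c1ccc(O)c([N+](=O)[O-])c1)SCc1ccc(Br)cc1)c1ccc(Cl)cc1Cl`: 10000 nM

Compound 2 gives 10000 nM, level with compound 3 and together the lowest of the three numbers. Compound 4 `O=C(/C(=C\c1ccc(O)c([N+](=O)[O-])c1)Sc1ccc(Br)cc1)c1ccc(Br)cc1` has 4-bromophenyl in place of 4-bromobenzyl on a sulfur. Going by the values given here, no measured step changes this group, so the others offer only a rough guide to size. Replacing the group on the carbonyl carbon gave a 5.0-fold lower number from compound 1 to compound 2 (0.70 log units; beyond the scatter) and no change at the digits printed from compound 2 to compound 3 (within the scatter). The direction of any change in this assay cannot be told from these data, so no shift beyond the scatter is expected, and the estimated step is no change at the digits printed from compound 2 to compound 4 (within the scatter). For compound 4 the expected value is 10000 nM, with an estimated range of 3500 nM to 30000 nM.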

Compound 4, concentration for 50% growth inhibition: 1000 nM
Estimate against measurement, compound 4: 10-fold (1.00 log units) above; the measured number lies below the stated range.
By their numbers in this assay, from the lowest: compound 4; then compounds 2 and 3 (each within the scatter of the next); then compound 1.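

Changing the group on the sulfur from 4-bromobenzyl to 4-bromophenyl gives a 10-fold lower number from compound 2 to compound 4 (1.00 log units; beyond the scatter) in this assay, a step beyond the scatter. Going by these compounds alone, the earlier compounds varied only the group on the carbonyl carbon, so this is the first sign that the group on the sulfur also moves the number. Nothing shown here explains this step. Still open, on these data alone, is how a longer chain on the sulfur, such as 2-phenylethyl, or an amine on its ring would behave. Also open, as far as these compounds go, is whether this change gives a similar step with 2,4-dichlorophenyl or 4-carboxyphenyl on the carbonyl carbon.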